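This account rests on a few compounds, and the source may have more. Where it says the series, first, only, none or still open, it means among the compounds named here.

Measured so far, in a functional assay on the whole organism (Abdomen, strain Swiss) for inhibition, with Mus musculus as the target, with a stated time of 1 h, at a dose of 100 umol/kg by the oral route; a higher number here means more inhibition at the dose given (going by the name of the read-out), a lower number less inhibition:
compound 1 `c1ccc(Nc2c(-c3ccccc3)nc3ccccn23)cc1` gives 10.8%;
compound 2 `CS(=O)(=O)c1ccc(Nc2c(-c3ccncc3)nc3ccccn23)cc1` gives 33.6%.

Compound 2 stands highest of the two numbers, and its nearest neighbour, compound 1, lies lower by a gap beyond the scatter. Compound 3 `c1ccc(Nc2c(-c3ccncc3)nc3ccccn23)cc1` arises from compound 2 by the change (hydrogen in place of methylsulfonyl on an aromatic carbon). Among the measured compounds shown here, no step between measured compounds covers this change, so the size of its effect is open. A downward step is expected, with the estimated step in this assay being a number 15.6 percentage points lower from compound 2 to compound 3 (beyond the scatter), possibly beyond the scatter. For compound 3 the estimate in this assay is 18%, with a range from 4% to 34%.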

Compound 3, a percentage reported as inhibition, in the whole organism at one dose (the size of the read-out at that dose, not a potency): 13%
Compound 3: middle estimate off by 5 percentage points, on the high side; the measured number falls inside the stated range.
By their numbers in this assay, from the lowest: compounds 1 and 3 (each within the scatter of the next); then compound 2.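

In this assay, the methylsulfonyl group on the aromatic carbon para to a large group accounts for a real difference: hydrogen in its place gives a number 20.6 percentage points lower from compound 2 to compound 3 (beyond the scatter). Pyridin-4-yl in place of phenyl gives only a number 2.2 percentage points higher from compound 1 to compound 3 (within the scatter) and so shows no effect of its own here. Nothing measured here speaks to the reason for either result.

As far as these compounds go, whether an amine, a carboxylic acid or a methyl group at that carbon would match methylsulfonyl remains open. So does whether methylsulfonyl gives a similar step alongside phenyl.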